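A few compounds are considered here, and "the series" means these few. Any claim that something is new, unique, unknown or untested is made for them only; others in the source may bear on it.

Measured in a functional assay on HGC-27 cells (Homo sapiens) for antiproliferative activity, read by MTT assay, with stated times of 72 h and 4 h; on this read-out higher numbers stand for weaker inhibition and lower numbers for stronger inhibition:
- compound 1 `COc1ncc(-c2cc3c(N4CC(C)OC(C)C4)ncnc3s2)cc1NS(=O)(=O)c1ccc(F)cc1F`: 860 nM
- compound 2 `COc1ncc(-c2cc3c(N4CCC(OC)CC4)ncnc3s2)cc1NS(=O)(=O)c1ccc(F)cc1F`: 280 nM
- compound 3 `COc1ncc(-c2nc3c(N4CCC(OC)CC4)ncnc3s2)cc1NS(=O)(=O)c1ccc(F)cc1F`: 74 nM

Compound 3 holds the lowest of these three numbers, and compound 2 lies nearest to it. The next structure, compound 4 `COc1ncc(-c2nc3c(N4CC5CCCC5C4)ncnc3s2)cc1NS(=O)(=O)c1ccc(F)cc1F`, carries this change: a group of 8 heavy atoms (7 carbon, 1 nitrogen; one five-membered non-aromatic ring of carbon only, one five-membered non-aromatic ring with 1 hetero atom) in place of a group of 8 heavy atoms (6 carbon, 1 nitrogen, 1 oxygen; one six-membered non-aromatic ring with 1 hetero atom), on an aromatic carbon. Among the compounds with values here, the only measured step that swaps such a group is a 3.1-fold lower number from compound 1 to compound 2 (0.49 log units; beyond the scatter), a modest step in which 4-methoxypiperidin-1-yl enters. Here that group leaves, so a step of similar modest size towards a higher number is expected in this assay, though one precedent on a different core is thin support. The expected change is a 2.3-fold higher number from compound 3 to compound 4 (0.36 log units; beyond the scatter). Compound 4 is estimated at 170 nM, within an expected range of 50 nM to 550 nM.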

Compound 4, half-maximal inhibitory concentration: 310 nM
For compound 4 the middle estimate is 1.8-fold (0.26 log units) below the measured one; the range from low to high includes it.
By their numbers in this assay, from the lowest: compound 3; then compounds 2 and 4 (each within the scatter of the next); then compound 1.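

In this assay, a 4.2-fold higher number from compound 3 to compound 4 (0.62 log units; beyond the scatter) shows that losing 4-methoxypiperidin-1-yl on the core of compound 3 also moves the number upward. Together with a 3.1-fold lower number from compound 1 to compound 2 (0.49 log units; beyond the scatter), this gives 4-methoxypiperidin-1-yl the lower number in both pairs, each against a different partner on a different core. No measurement at hand explains this difference. As far as these compounds go, what remains open is whether the methoxy group itself matters, which plain piperidin-1-yl would test. Whether 4-aminopiperidin-1-yl or 4-hydroxypiperidin-1-yl would hold, lower or raise the number at this position also stays unanswered.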